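A few compounds are considered here, and "the series" means these few. Any claim that something is new, unique, unknown or untested is made for them only; others in the source may bear on it.

Measured compounds in the series:
- Compound 1, `CCC(C)NC(=O)c1cc2c(C)cc(C)cc2[nH]1`: in a physicochemical assay for solubility, measured as thermodynamic solubility, with a stated time of 24 h, at pH 6.8 (a higher number here means a more soluble compound, a lower number a less soluble compound), compound 1 gives 22000 nM.
- Compound 2, `CCC(CC)NC(=O)c1cc2c(C)cc(C)cc2[nH]1`: in this assay compound 2 gives only a limit, < 4000 nM.
- Compound 3, `Cc1cc(C)c2cc(C(=O)N[C@@H]3CCCC[C@@H]3C)[nH]c2c1`: in this assay compound 3 gives only a limit, < 4000 nM.

Compound 3 thus stands at the low edge of what has been seen, with no figure of its own; the same holds for (the limit of < 4000 nM in this assay, at which 2 of the 3 values shown sit). Enlarging the group on the amide-type nitrogen has so far only lowered the number: an at least 5.5-fold lower number from compound 1 to compound 2 (0.74 log units; beyond the scatter), and an at least 5.5-fold lower number from compound 1 to compound 3 (0.74 log units; beyond the scatter). Between the two limits, a step that the two limits leave unreadable from compound 2 to compound 3.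

Compound 4, `COCCNC(=O)c1cc2c(C)cc(C)cc2[nH]1`, differs from compound 3 as follows: 2-methoxyethyl in place of 2-methylcyclohexyl on an amide-type nitrogen. The step that bears on it is the one from sec-butyl to 2-methylcyclohexyl, run here in the opposite sense, since the six-membered ring leaves and a shorter chain carrying an oxygen enters. A rise in this assay beyond the scatter is therefore expected, at least back to the region of compound 1. Compound 4 is expected to give about 60000 nM, within 15000 nM to 250000 nM. The expected step is an at least 15-fold higher number from compound 3 to compound 4 (1.17 log units; beyond the scatter).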

Compound 4, solubility: 620000 nM
The estimate for compound 4 lay 10-fold (1.01 log units) below the measured number; the measured number lies above the stated range.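

With 2-methoxyethyl in place of sec-butyl on the amide-type nitrogen, this assay gives the first rise at this position, a 28-fold higher number from compound 1 to compound 4 (1.45 log units; beyond the scatter), so changes here no longer only lower the number. Against the two larger groups, the change gives an at least 150-fold higher number from compound 2 to compound 4 (2.19 log units; beyond the scatter) and an at least 150-fold higher number from compound 3 to compound 4 (2.19 log units; beyond the scatter), which places the range spanned by this one position on the shared core well beyond the scatter. Compound 2 and compound 3 each give only a limit, so both of these steps are minimum sizes: the limit of < 4000 nM in this assay, at which 2 of the 4 values shown sit.

Open, as far as these compounds go, is how a straight butyl chain or a 2-hydroxyethyl group would compare with 2-methoxyethyl, and so whether the step goes with the oxygen or with the unbranched chain. Also open, from the compounds shown here alone, is whether a step of this size would carry over to a different core.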